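Methyl to chloro on a weakly active compound

The compounds below may be only part of what the source reports. "The series", "measured", "known", "first", "only" and "open" are said of these compounds alone.

Compounds sharing one core were tested in a functional assay on SGC-7901 cells (Homo sapiens) for antiproliferative activity, read by MTT assay, with a stated time of 24 h; a lower number here means a stronger inhibitor, a higher number a weaker inhibitor. Compound 1 (`Cc1ccccc1NNC(=O)c1cccc(NS(=O)(=O)c2cnc(O)nc2O)c1`) gives > 20000 nM, which is a limit of the assay. Compound 3 (`Cc1ccccc1C(=O)NNC(=O)c1cccc(NS(=O)(=O)c2cnc(O)nc2O)c1`) gives > 20000 nM, also a limit. Compound 2 (`CCCCOc1ccc(C(=O)NNC(=O)c2cccc(NS(=O)(=O)c3cnc(O)nc3O)c2)cc1`) gives a true number, 7370 nM. Compound 3 thus stands at the limit of > 20000 nM in this assay, at which 2 of the 3 values shown sit.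

Compound 4 (`O=C(NNC(=O)c1ccccc1Cl)c1cccc(NS(=O)(=O)c2cnc(O)nc2O)c1`) has chloro in place of methyl on an aromatic carbon, ortho to a large group: chloro in place of methyl on an aromatic carbon. Going by the values given here, two measured steps bear on this change, and neither makes the same swap. The step to compound 3 from its 4-butoxyphenyl partner is an at least 2.7-fold higher number from compound 2 to compound 3 (0.43 log units; beyond the scatter). The other, a step that the two limits leave unreadable from compound 1 to compound 3, gives no size. Compound 4 keeps the small ortho-substituted phenyl pattern of compound 3, so no step beyond the scatter is expected in this assay, and no direction can be called. The expected step is a number no higher from compound 3 to compound 4 (the limit leaves the size open). For compound 4 the estimated value is 20000 nM, with an expected range of 10000 nM to 40000 nM.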

Compound 4, half-maximal inhibitory concentration: 6070 nM
For compound 4 the middle estimate is 3.3-fold (0.52 log units) above the measured one; measured number below the stated range.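

Changing methyl to chloro on the aromatic carbon ortho to a large group gives the first readable effect of a change at this position in this assay, with an at least 3.2-fold lower number from compound 3 to compound 4 (0.51 log units; beyond the scatter). This single-atom swap also brings the 2-chlorophenyl compound level with the 4-butoxyphenyl compound, with a 1.2-fold lower number from compound 2 to compound 4 (0.08 log units; within the scatter), and separates it from the compound carrying 2-methylphenyl on an amine nitrogen, with an at least 3.2-fold lower number from compound 1 to compound 4 (0.51 log units; beyond the scatter). The true size of the two steps from the weak compounds remains unknown because each starts from a limit of the assay: the limit of > 20000 nM in this assay, at which 2 of the 4 values shown sit.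

The compounds shown leave open whether fluoro, bromo or methoxy at this position would behave like chloro. They also cannot say whether the same swap would give a similar step on another core.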